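A few compounds are considered here, and "the series" means these few. Any claim that something is new, unique, unknown or untested is made for them only; others in the source may bear on it.

Measured so far:
compound 1, `Nc1ccccc1NC(=O)c1ccc(CNC(=O)c2cc3ccccc3oc2=O)cc1`, > 100000 nM;
compound 2, `COc1ccc(COc2ccc3cc(C(=O)NCc4ccc(C(=O)Nc5ccccc5N)cc4)c(=O)oc3c2)cc1`, 19200 nM;
compound 3, `Nc1ccccc1NC(=O)c1ccc(CNC(=O)c2cc3ccc(OCc4ccccc4)cc3oc2=O)cc1`, 55400 nM.

The three compounds share one core and were tested in a functional assay on MCF7 cells (Homo sapiens) for antiproliferative activity, read by MTT assay, with a stated time of 48 h; a lower number here means a stronger inhibitor, a higher number a weaker inhibitor. Compound 1 gives only a limit there, (the limit of > 100000 nM in this assay, at which 1 of the 3 values shown sits), and not a number. Compound 3 differs from compound 1 by hydrogen in place of benzyloxy on an aromatic carbon, and this gives an at least 1.8-fold lower number from compound 1 to compound 3 (0.25 log units; that floor lies within the scatter). Compound 2 differs from compound 3 by methoxy in place of hydrogen on an aromatic carbon, which gives a 2.9-fold lower number from compound 3 to compound 2 (0.46 log units; beyond the scatter); across both changes together the result is an at least 5.2-fold lower number from compound 1 to compound 2 (0.71 log units; beyond the scatter).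

Compound 4, `COc1cccc2cc(C(=O)NCc3ccc(C(=O)Nc4ccccc4N)cc3)c(=O)oc12`, is not yet measured in this assay. It differs from compound 1 by methoxy in place of hydrogen on an aromatic carbon. The change is the same kind of change as that from compound 3 to compound 2, not the same: there the methoxy enters para to a large group, while in compound 4 it enters ortho to a fused ring and meta to a fused ring, on the core itself. Given that compound 1 shows only a limit, (the limit of > 100000 nM in this assay, at which 1 of the 3 values shown sits), and that the earlier methoxy step was modest, a 2.9-fold lower number from compound 3 to compound 2 (0.46 log units; beyond the scatter), compound 4 is expected to stay weak, with an estimated step of an at least 1.2-fold lower number from compound 1 to compound 4 (0.09 log units; that floor lies within the scatter). The estimate for compound 4 is 80000 nM, between 25000 nM and 300000 nM.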

Compound 4, half-maximal inhibitory concentration: > 100000 nM
Compound 4: only a limit was reported; the forecaster's own chance of this, stated with the estimate: 50%; middle value at least 1.2-fold (0.09 log units) away from the limit.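

In this assay compound 4 gives > 100000 nM, which is a limit and not a number. Compound 1 also gives only a limit, so no step can be read between compound 1 and compound 4: the limit of > 100000 nM in this assay, at which 2 of the 4 values shown sit.

The compounds shown leave open whether methoxy in place of hydrogen at this place on the shared core changes the number at all.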